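The compounds below may be only part of what the source reports. "The series", "measured", "known", "first", "only" and "open" are said of these compounds alone.

Measured in an ADME assay on HepG2 cells (Homo sapiens) for cytotoxicity, read by CellTiter-Glo and resazurin assay, with a stated time of 72 h; on this read-out lower numbers stand for an effect already at smaller amounts and higher numbers for an effect only at larger amounts of compound:
Compound 1 `CC(C)N(Cc1cccc(OCCCCCC(=O)O)c1)C(=O)c1ccccc1` gives > 26000 nM, a limit of the assay.
Compound 2 `CC(=O)c1cccc(-c2ccc(C(=O)N(Cc3cccc(OCCCCCC(=O)O)c3)C(C)C)cc2)c1` gives > 26000 nM, a limit of the assay.
Compound 3 `CC(C)N(Cc1cccc(OCCCCCC(=O)O)c1)C(=O)c1ccc(-c2ccoc2)cc1` gives > 26000 nM, a limit of the assay.

Compound 3 stands at the same limit as the other two members, so no numbered value is known anywhere in the series, as the limit of > 26000 nM in this assay, at which 3 of the 3 values shown sit, records. The steps a step that the two limits leave unreadable from compound 1 to compound 2, a step that the two limits leave unreadable from compound 1 to compound 3 and a step that the two limits leave unreadable from compound 2 to compound 3 are all left unreadable by the two limits, whatever the size of the exchanged group. Compound 4 `CC(C)N(Cc1cccc(OCCCCCC(=O)O)c1)C(=O)c1ccc(-c2ccsc2)cc1` differs from compound 3 by thiophen-3-yl in place of furan-3-yl on an aromatic carbon. Among the compounds with values here, none of the measured steps gives a readable size, so for the step in this assay no direction and no size beyond the scatter can be anticipated; the only guide is that every measured member sits at the limit, as the limit of > 26000 nM in this assay, at which 3 of the 3 values shown sit, shows. Compound 4 is accordingly expected to come out near 40000 nM, within 20000 nM to 120000 nM, and most likely to be reported as a limit once more. The step that the limit leaves unreadable from compound 3 to compound 4 is estimated to stay within the scatter.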

Compound 4, half-maximal effective concentration: > 26000 nM
Compound 4: only a limit was reported (the forecaster's own chance of this, stated with the estimate: 90%); the middle value is on the limit's open side.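

In this assay compound 4 gives > 26000 nM, again a limit. Within the data shown here, no step from compound 1, compound 2 or compound 3 to compound 4 can be read, as all four compounds stand at the limit: the limit of > 26000 nM in this assay, at which 4 of the 4 values shown sit. The compounds shown leave open at what concentration any of them would reach a half-maximal effect, and whether the exchanged groups make any difference to it.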